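The compounds below may be only part of what the source reports. "The series", "measured", "known", "first", "only" and "open" are said of these compounds alone.

Compounds measured in a functional assay on K562 cells (Homo sapiens) for antiproliferative activity, with a stated time of 72 h; on this read-out higher numbers stand for weaker inhibition and lower numbers for stronger inhibition:
- compound 1 `OC[C@H]1O[C@@H](n2cnc3c(NCc4ccccc4F)ncnc32)[C@H](O)[C@@H]1O` gives 33200 nM
- compound 2 `OC[C@H]1O[C@@H](n2cnc3c(NCc4ccc(Cl)cc4)ncnc32)[C@H](O)[C@@H]1O` gives 218000 nM
- compound 3 `COc1cccc(CNc2ncnc3c2ncn3[C@@H]2O[C@H](CO)[C@@H](O)[C@H]2O)c1O` gives 27900 nM

Compound 2 has the highest number of the three, standing a 6.6-fold higher number from compound 1 to compound 2 (0.82 log units; beyond the scatter) and a 7.8-fold lower number from compound 2 to compound 3 (0.89 log units; beyond the scatter). Compound 4 `Cc1ccc(O)c(CNc2ncnc3c2ncn3[C@@H]2O[C@H](CO)[C@@H](O)[C@H]2O)c1` differs from compound 2 as 2-hydroxy-5-methylphenyl in place of 4-chlorophenyl on a saturated chain carbon bound to a nitrogen on an aromatic ring. The step that bears on it most directly is a 7.8-fold lower number from compound 2 to compound 3 (0.89 log units; beyond the scatter), where a phenyl ring carrying a hydroxy group also replaced the 4-chlorophenyl; the step of a 6.6-fold higher number from compound 1 to compound 2 (0.82 log units; beyond the scatter) shows in the other direction how far 4-chlorophenyl lags. A lowering of similar size is therefore expected in this assay, estimated at a 6.2-fold lower number from compound 2 to compound 4 (0.79 log units; beyond the scatter). Compound 4 is expected to give 35000 nM, with a range from 12000 nM to 100000 nM.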

Compound 4, half-maximal inhibitory concentration: 16500 nM
The estimate for compound 4 lay 2.1-fold (0.33 log units) above the measured number, and the stated range covers the measured number.
By their numbers in this assay, from the lowest: compounds 4, 3 and 1 (each within the scatter of the next); then compound 2.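

In this assay, a second phenyl ring carrying a hydroxy group also stands well clear of 4-chlorophenyl, a 13-fold lower number from compound 2 to compound 4 (1.12 log units; beyond the scatter), so compound 2 is the one that departs from the others at this position. The remaining rings cannot be ordered, as a 1.7-fold lower number from compound 3 to compound 4 (0.23 log units; within the scatter) and a 2.0-fold lower number from compound 1 to compound 4 (0.30 log units; within the scatter) both lie within the scatter, and a hydroxy group is therefore not shown to matter when compared with 2-fluorophenyl. No measurement here bears on the reason for the gap.

The compounds shown leave open whether the chlorine itself sets compound 2 apart. They also leave open how a ring carrying an amine or a carboxylic acid, or a longer chain to the ring, would behave here.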